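Swapping the aryl group on the ring nitrogen of compound 3

This account rests on a few compounds, and the source may have more. Where it says the series, first, only, none or still open, it means among the compounds named here.

The series shares one core carrying an aryl group on the amide-type nitrogen of the five-membered ring and an amide-linked chain on the attached benzene. Compound 1, `O=C(NCCCCn1cccn1)c1cccc(C2SCC(=O)N2c2cccnc2)c1`, gives > 1000 nM in a functional assay on HOS-TE85 cells (Homo sapiens) for inhibition, read by CCK-8 assay, with a stated time of 72 h; a higher number here means a weaker inhibitor, a lower number a stronger inhibitor; that value is a limit of the assay, not a number. Compound 2, `COc1ccccc1N1C(=O)CSC1c1cccc(C(=O)NCCCCc2ccc(Cl)cc2)c1`, gives 78.6 nM in this assay. Compound 3, `O=C(NCCCCc1ccccc1)c1cccc(C2SCC(=O)N2c2cccc(F)c2)c1`, gives 32.4 nM in this assay and so stands lowest of the two numbers, with compound 2 the nearest at a gap beyond the usual scatter.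

Compound 4, `COc1ccc(N2C(=O)CSC2c2cccc(C(=O)NCCCCc3ccccc3)c2)c(OC)c1`, is the next candidate. It differs from compound 3 in a single place: 2,4-dimethoxyphenyl in place of 3-fluorophenyl on an amide-type nitrogen in a ring. For the measured compounds named here, no measured pair isolates this change, so its size is open. Compound 2, which also carries a methoxy-bearing aryl on that nitrogen, gives a higher number than compound 3, and a step upward of a similar, modest size is expected here, from compound 3 to compound 4 of a 2.8-fold higher number from compound 3 to compound 4 (0.44 log units; beyond the scatter). Compound 4 is therefore estimated at 90 nM in this assay, with a plausible range of 30 nM to 300 nM.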

Compound 4, half-maximal inhibitory concentration: 90.4 nM
Beside the measured number, compound 4's estimate is 1.0-fold (0.00 log units) below it, and the stated range covers the measured number.
By their numbers in this assay, from the lowest: compound 3; then compounds 2 and 4 (each within the scatter of the next). At a limit, above all of these: compound 1.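

For the compounds shown here, this is the first pair that isolates the aryl group on the amide-type nitrogen in a ring: with the rest of the structure unchanged, 2,4-dimethoxyphenyl in place of 3-fluorophenyl gives a 2.8-fold higher number from compound 3 to compound 4 (0.45 log units; beyond the scatter) in this assay. The position therefore accepts a larger aryl group with two methoxy groups and no fluorine, at the cost of a modest step, and the result remains a measured number rather than a limit of the assay. Nothing measured here explains the size or direction of this step.

This single pair cannot separate the loss of the fluorine from the gain of either methoxy group, and a plain phenyl or a phenyl bearing one methoxy group on the same nitrogen, with the chain of compound 3 kept, would be needed to divide the step into its parts. Compound 1 and compound 2 each differ from compound 3 in more than one place, so their steps cannot be read, and the separate contributions of the ring nitrogen of the pyridine, the chlorine and the pyrazole remain unresolved.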